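The source may hold more compounds than are shown below. What is called first, only, known or untested is meant among the compounds shown, and "the series" means these compounds.

In a functional assay (a lower number here means a stronger inhibitor, a higher number a weaker inhibitor), compound 1 `CC(C)=CCOc1cc(O)c2c(c1)OC(c1cccc(Cl)c1)CC2=O` gives 6060 nM and compound 2 `CC(C)=CCOc1cc(O)c2c(c1)OC(c1ccc(Cl)cc1)CC2=O` gives 7020 nM, with a 1.2-fold higher number from compound 1 to compound 2 (0.06 log units; within the scatter). Compound 3 `CC(C)=CCOc1cc(O)c2c(c1)OC(c1ccc(Cl)cc1Cl)CC2=O` gives 3340 nM, and it stands against those two with a 1.8-fold lower number from compound 1 to compound 3 (0.26 log units; within the scatter) and a 2.1-fold lower number from compound 2 to compound 3 (0.32 log units; beyond the scatter). Compound 4 `CC(C)=CCOc1cc(O)c2c(c1)OC(c1ccc(O)cc1)CC2=O` carries 4-hydroxyphenyl in place of 2,4-dichlorophenyl on a saturated ring carbon. Going by the values given here, no measured step covers a hydroxy group, so the steps between the chlorinated compounds are only a rough guide. The nearest is the modest 2.1-fold lower number from compound 2 to compound 3 (0.32 log units; beyond the scatter), read here in reverse, since compound 4 lacks the added chloro. A modest step to a higher number is therefore expected in this assay. The estimated step is a 1.9-fold higher number from compound 3 to compound 4 (0.29 log units; within the scatter). Compound 4 is expected at 6500 nM, within an estimated range of 2000 nM to 20000 nM.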

Compound 4, half-maximal inhibitory concentration: 5340 nM
Compound 4: middle estimate off by 1.2-fold (0.09 log units), on the high side; the measured number falls inside the stated range.
By their numbers in this assay, from the lowest: compounds 3, 4, 1 and 2 (each within the scatter of the next, the first and the last beyond it).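

On the saturated ring carbon next to the ring oxygen, a hydrogen-bond donor now enters the series, and in this assay hydroxy in place of chloro gives a 1.3-fold lower number from compound 2 to compound 4 (0.12 log units; within the scatter) as its step. The other two exchanges, a 1.6-fold higher number from compound 3 to compound 4 (0.20 log units; within the scatter) and a 1.1-fold lower number from compound 1 to compound 4 (0.05 log units; within the scatter), also remain inside the scatter, so compound 4 cannot be separated from any of the chlorinated compounds. No supporting data bear on this result. Going by these compounds, whether an amine, a carboxylic acid or a methoxy group on this phenyl ring would keep the number in this range remains open, as does whether any group here gives a larger step.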